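Swapping the benzamide ring for a pyridine in an A3 series

The source may hold more compounds than are shown below. What is called first, only, known or untested is meant among the compounds shown, and "the series" means these compounds.

Compounds measured so far:
compound 1 `Cc1nc(NC(=O)c2ccccc2)c2nn(-c3ccccc3)cc2n1`: 5.6 nM
compound 2 `O=C(Nc1nc(-c2ccccc2)nc2cn(-c3ccccc3)nc12)c1ccco1`: 24 nM
compound 3 `O=C(Nc1nc(-c2ccccc2)nc2cn(-c3ccccc3)nc12)c1ccccc1`: 20 nM

These three compounds share one core and were all tested in an assay on CHO cells for displacement of a labelled ligand from adenosine receptor A3 (Homo sapiens), read by scintillation counting, with a stated time of 60 min; a lower number here means a stronger inhibitor, a higher number a weaker inhibitor. Compound 1 gives 5.6 nM, compound 2 gives 24 nM, and compound 3 gives 20 nM. Compound 3 thus stands second highest of the three numbers; its nearest neighbour is compound 2, which lies within the scatter of it, while the gap to compound 1 is beyond the scatter, as a 3.6-fold higher number from compound 1 to compound 3 (0.55 log units; beyond the scatter) shows.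

Compound 4 `O=C(Nc1nc(-c2ccccc2)nc2cn(-c3ccccc3)nc12)c1ccncc1` differs from compound 3 only at the amide: pyridin-4-yl in place of phenyl on a carbonyl carbon. The step that bears on this is the one at the same carbonyl carbon, a 1.2-fold lower number from compound 2 to compound 3 (0.08 log units; within the scatter), where exchanging furan-2-yl for phenyl stayed within the scatter. This shows that a heteroaromatic ring on the carbonyl carbon is tolerated without a step beyond the scatter. For compound 4 no step beyond the scatter is therefore expected in this assay, so a 1.5-fold higher number from compound 3 to compound 4 (0.18 log units; within the scatter) is anticipated. Compound 4 is accordingly estimated at 30 nM, with a likely range from 10 nM to 90 nM.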

Compound 4, inhibition constant: 25 nM
Compound 4: the middle estimate sits 1.2-fold (0.08 log units) above what was measured, and the stated range covers the measured number.
By their numbers in this assay, from the lowest: compound 1; then compounds 3, 2 and 4 (each within the scatter of the next).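

At the carbonyl carbon, the earlier compounds had shown only that furan-2-yl and phenyl read alike, whereas a six-membered aromatic ring carrying a nitrogen now proves equally acceptable in this assay. Pyridin-4-yl in place of phenyl gives a 1.3-fold higher number from compound 3 to compound 4 (0.10 log units; within the scatter) and pyridin-4-yl in place of furan-2-yl gives a 1.0-fold higher number from compound 2 to compound 4 (0.02 log units; within the scatter), so all three rings on this carbonyl carbon lie within the scatter of one another, even though pyridin-4-yl brings a hydrogen-bond acceptor that phenyl lacks. No available evidence accounts for this flat response at the position.

The compounds shown leave open whether a non-aromatic group on the carbonyl carbon, such as cyclohexyl or a longer alkyl chain, would read the same. They also leave open whether pyridin-4-yl would be tolerated equally on the core of compound 1, which carries methyl in place of phenyl on an aromatic carbon.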